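Second chloro on the benzyl group of the shared core

A few compounds are considered here, and "the series" means these few. Any claim that something is new, unique, unknown or untested is made for them only; others in the source may bear on it.

Measured so far:
compound 1, `NC(=O)c1c(NC(=O)c2ccccc2Cl)sc2c1CCN(Cc1ccccc1)C2`: 14500 nM
compound 2, `NC(=O)c1c(NC(=O)c2ccccc2Cl)sc2c1CCN(Cc1ccccc1Cl)C2`: 4430 nM

In a functional assay on MKN-74 cells (Homo sapiens) for antiproliferative activity, with a stated time of 24 h (a higher number here means a weaker inhibitor, a lower number a stronger inhibitor), compound 2 gives the lowest of the two numbers; compound 1 sits above it, and the step of a 3.3-fold lower number from compound 1 to compound 2 (0.51 log units; beyond the scatter) lies beyond the scatter.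

Compound 3, `NC(=O)c1c(NC(=O)c2ccccc2Cl)sc2c1CCN(Cc1ccc(Cl)cc1Cl)C2`, is not yet measured. It differs from compound 2 by chloro in place of hydrogen on an aromatic carbon, that is, 2-chlorobenzyl becomes 2,4-dichlorobenzyl.

Going by the values given here, the only measured step that speaks to this is the one from compound 1 to compound 2, where the first chloro on the benzyl group was introduced: a 3.3-fold lower number from compound 1 to compound 2 (0.51 log units; beyond the scatter). A second chloro on the same ring, at another position, is a related but not identical change, so a smaller gain than that step, or none beyond the scatter, seems the fair reading.

For compound 3 the expected value in this assay is therefore 2500 nM, with a range of 900 nM to 7000 nM. This estimate for compound 3 means a step of a 1.8-fold lower number from compound 2 to compound 3 (0.25 log units; within the scatter).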

Compound 3, half-maximal inhibitory concentration: 16300 nM
The estimate for compound 3 lay 6.5-fold (0.81 log units) below the measured number; measured number above the stated range.
By their numbers in this assay, from the lowest: compound 2; then compounds 1 and 3 (each within the scatter of the next).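

In this assay, the same replacement of hydrogen by chloro on the benzyl ring does not act the same way at each place: the chloro para to a large group and meta to a chloro group reverses the earlier direction, with a 3.7-fold higher number from compound 2 to compound 3 (0.57 log units; beyond the scatter), against a 3.3-fold lower number from compound 1 to compound 2 (0.51 log units; beyond the scatter). The 2,4-dichlorobenzyl and unsubstituted benzyl groups are not separated, with a 1.1-fold higher number from compound 1 to compound 3 (0.05 log units; within the scatter) within the scatter, so among these compounds the gain seen with 2-chlorobenzyl does not carry over to 2,4-dichlorobenzyl. No supporting data bear on the reason for this reversal.

Going by these compounds, it remains open whether the higher number of compound 3 is specific to chloro at this place or would also follow with another group there, such as fluoro, methyl or methoxy. A 4-chlorobenzyl group without the second chloro would show whether this place acts alone or only in combination.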